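The source may report more compounds than this note shows. Statements on the series, on what has been measured and on what is new or still open speak of the compounds shown alone.

Among the compounds with values here, compound 1 `CCCS(=O)(=O)Nc1ccc(F)c(C(=O)c2n[nH]c3ncc(-c4ccc(O)cc4)cc23)c1F` gives 0.75% in an assay for binding affinity to dual specificity mitogen-activated protein kinase kinase 4 (Homo sapiens), read by KINOMEscan, tested at 100 nM; a higher number here means a weaker effect of the compound at the concentration tested, a lower number a stronger effect; compound 2 `CCCS(=O)(=O)Nc1ccc(F)c(C(=O)c2n[nH]c3ncc(-c4ccc(Cl)cc4Cl)cc23)c1F` gives 22%, which is the higher of the two numbers so far, the step of a number 21.3 percentage points higher from compound 1 to compound 2 (beyond the scatter) lying beyond the scatter. Compound 3 `CCCS(=O)(=O)Nc1ccc(F)c(C(=O)c2n[nH]c3ncc(-c4ccc(S(N)(=O)=O)cc4Cl)cc23)c1F` differs from compound 2 by sulfamoyl in place of chloro on an aromatic carbon, the same change read further out being 2,4-dichlorophenyl to 2-chloro-4-sulfamoylphenyl. Within the data shown here, only the step from compound 1 to compound 2 bears on this, and it was modest; a donor-bearing group returning at the site para to a large group suggests a move back toward the lower number. For compound 3 the expected step is a number 14 percentage points lower from compound 2 to compound 3 (beyond the scatter), giving an estimate of 8% with a range of 1% to 35%.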

Compound 3, a percentage reported as activity, at one concentration (the size of the read-out at that concentration, not a potency): 3.4%
Estimate against measurement, compound 3: 4.6 percentage points above; the measured number falls inside the stated range.
By their numbers in this assay, from the lowest: compounds 1 and 3 (each within the scatter of the next); then compound 2.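

At the position para to a large group, sulfamoyl in place of chloro gives a number 18.6 percentage points lower from compound 2 to compound 3 (beyond the scatter) and so undoes the rise seen with 2,4-dichlorophenyl, even though one chloro group stays on the ring. The 2-chloro-4-sulfamoylphenyl group stands level with 4-hydroxyphenyl, with a number 2.7 percentage points higher from compound 1 to compound 3 (within the scatter) in this assay and the remaining chloro group showing no cost at this level. No measurement here gives a reason for either step.

On these data alone, whether the lower number depends on sulfamoyl itself remains open. An amine or a carboxylic acid at this position, or 4-sulfamoylphenyl without the chloro group, would test that.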